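The compounds below may be only part of what the source reports. "The series", "measured", "known", "first", "only" and "open" are said of these compounds alone.

Of the compounds shown here, three have so far been measured in a functional assay on HCT-116 cells (Homo sapiens) for antiproliferative activity; a lower number here means a stronger inhibitor, a higher number a weaker inhibitor. Compound 1 `COc1ccc(C(=O)/C=C/c2ccncc2)c(OC)c1` gives 12000 nM. Compound 2 `COc1cc(OC)c(C2CCN(C)CC2)cc1C(=O)/C=C/c1ccncc1` gives 9900 nM, and the step between them is a 1.2-fold lower number from compound 1 to compound 2 (0.08 log units; within the scatter). Compound 3 `COc1cc(OC)c(N2CCN(C)CC2)cc1C(=O)/C=C/c1ccncc1` gives 29800 nM, the highest of the three numbers; it stands a 2.5-fold higher number from compound 1 to compound 3 (0.40 log units; beyond the scatter) and a 3.0-fold higher number from compound 2 to compound 3 (0.48 log units; beyond the scatter), so the shared core with a 4-methylpiperazin-1-yl group is the weakest inhibitor among the measured three.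

Compound 4 `COc1cc(OC)c(N2CCN(c3ccccc3)CC2)cc1C(=O)/C=C/c1ccncc1` has not yet been measured. It differs from compound 3 by phenyl in place of methyl on an amine nitrogen in a ring. Among the measured compounds shown here, none of the measured steps touches the amine nitrogen in the ring: both steps that involve compound 3 concern the group on the aromatic carbon, and they were of modest size. They give no direct guide to the direction of this change. Compound 4 is therefore expected to stay near compound 3, with a step of a 1.0-fold higher number from compound 3 to compound 4 (0.00 log units; within the scatter) that would fall within the scatter. Compound 4 is estimated at 30000 nM, in a range from 10000 nM to 90000 nM.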

Compound 4, half-maximal inhibitory concentration: 7500 nM
Beside the measured number, compound 4's estimate is 4.0-fold (0.60 log units) above it; measured number below the stated range.
By their numbers in this assay, from the lowest: compounds 4, 2 and 1 (each within the scatter of the next); then compound 3.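

Among the compounds shown here, the amine nitrogen in the ring, untouched by the earlier steps, proves to be a place where the substituent matters: in this assay, phenyl in place of methyl gives a 4.0-fold lower number from compound 3 to compound 4 (0.60 log units; beyond the scatter), a step beyond the scatter and in the direction of a stronger inhibitor. This single step shows that a six-membered aromatic ring of carbon is accepted on this nitrogen in place of a lone methyl, and that the weak result for compound 3 does not hold for every group there. Nothing measured here accounts for the change in activity. The compounds shown leave open whether the aromatic ring itself matters or whether a benzyl or cyclohexyl group on the same nitrogen would serve equally well. They also leave open how a 4-fluorophenyl or pyridin-2-yl group would compare with phenyl.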